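Amino core: isopropoxy to cyclopentylamino, compound 1 to compound 3

The compounds below may be only part of what the source reports. "The series", "measured", "known", "first", "only" and "open" are said of these compounds alone.

compound 1 `COc1ccc(-c2cnc3nc(N)nc(OC(C)C)c3n2)cc1OC`: 400 nM
compound 2 `COc1ccc(-c2cnc3nc(N)nc(OC(C)C)c3n2)cc1`: > 10000 nM

Among the compounds with values here, in a functional assay on cells (T-cell, Homo sapiens) for inhibition (on this read-out higher numbers stand for weaker inhibition and lower numbers for stronger inhibition), compound 1 gives 400 nM, the only plain number among the two values shown. Compound 2 sits at a limit of the assay, not at a number. Compound 2 differs from compound 1 by hydrogen in place of methoxy on an aromatic carbon, and that step is an at least 25-fold higher number from compound 1 to compound 2 (1.39 log units; beyond the scatter), its size fixed by the limit of > 10000 nM in this assay, at which 1 of the 2 values shown sits.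

Compound 3 `COc1ccc(-c2cnc3nc(N)nc(NC4CCCC4)c3n2)cc1OC` is not yet measured; it differs from compound 1 by cyclopentylamino in place of isopropoxy on an aromatic carbon. Within the data shown here, no measured step bears on this exchange: the one step known removes a methoxy and leaves the isopropoxy untouched, so it gives no guide to isopropoxy against cyclopentylamino. In this assay the step to compound 3 is therefore expected to stay within the scatter, in either direction. Compound 3 is estimated at 300 nM, within 60 nM to 1500 nM, which would mean a 1.3-fold lower number from compound 1 to compound 3 (0.12 log units; within the scatter).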

Compound 3, half-maximal inhibitory concentration: 800 nM
Beside the measured number, compound 3's estimate is 2.7-fold (0.43 log units) below it; measured number inside the range.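

In this assay, the position on the aromatic carbon next to the ring nitrogen tolerates a larger substituent: a 2.0-fold higher number from compound 1 to compound 3 (0.30 log units; within the scatter). The exchange brings in a five-membered non-aromatic ring and a hydrogen-bond donor, and the read-out does not separate compound 3 from compound 1. The removal of a methoxy remains the only step beyond the scatter, and its size is set by a limit: the limit of > 10000 nM in this assay, at which 1 of the 3 values shown sits.

From the compounds shown here alone, it remains open whether isopropylamino, which would separate the change from oxygen to nitrogen from the addition of the ring, or a morpholine or longer alkylamino chain would stay within the same range at this position. Going by these compounds, it is also open whether removing the same methoxy from compound 3 would have an effect of similar size.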